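This account rests on a few compounds, and the source may have more. Where it says the series, first, only, none or still open, it means among the compounds named here.

Measured compounds:

Compound 1, `CCCc1cc(N)c2cc(NC(=O)/C=C/c3ccc(F)cc3)ccc2n1`: 200 nM
Compound 2, `CCCc1cc(N)c2cc(NC(=O)c3ccc(-c4ccc(Cl)cc4)cc3)ccc2n1`: 75 nM
Compound 3, `CCc1cc(N)c2cc(NC(=O)/C=C/c3ccc(C(F)(F)F)cc3)ccc2n1`: 110 nM

In a functional assay on HEK293 cells for activation of melanin-concentrating hormone receptor 1 (Homo sapiens), read by inositol phosphate accumulation (a higher number here means that more compound is needed for the effect, a lower number that less compound is needed), compound 1 gives the highest of the three numbers. Compound 3 gives 110 nM, which lies within the scatter of compound 1, so no order between those two can be read. Compound 2 gives 75 nM, which sits beyond the scatter below compound 1.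

Compound 4, `CCCc1cc(N)c2cc(NC(=O)/C=C/c3ccc(I)cc3)ccc2n1`, has not yet been measured. It differs from compound 1 in one place: iodo in place of fluoro on an aromatic carbon, that is, on an aromatic carbon of a six-membered aromatic ring of carbon only, para to a large group. Within the data shown here, no measured pair shows this exact exchange, so the size of the step cannot be taken from data; the numbers for compound 2 and compound 3 only show that other groups at this position are tolerated.

Compound 4 is estimated at 110 nM in this assay, with a range from 40 nM to 300 nM. The expected step from compound 1 to compound 4 is a 1.8-fold lower number from compound 1 to compound 4 (0.26 log units; within the scatter), a small move toward a lower number, at the edge of the scatter.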

Compound 4, half-maximal effective concentration: 280 nM
Compound 4: middle estimate off by 2.5-fold (0.41 log units), on the low side, and the stated range covers the measured number.
By their numbers in this assay, from the lowest: compounds 2, 3, 1 and 4 (each within the scatter of the next, the first and the last beyond it).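

In this assay, among these compounds, iodo in place of fluoro on an aromatic carbon para to a large group gives a 1.4-fold higher number from compound 1 to compound 4 (0.15 log units; within the scatter), the first directly readable step at this position. The 4-fluorophenyl and 4-iodophenyl compounds cannot be told apart here, so this single exchange gives no sign that the number depends on which of these two halogens is present. Nothing at hand gives a reason for this outcome.

On these data alone, it remains open whether this holds beyond these two halogens: an amine, a carboxylic acid or a methoxy group on the same carbon would test it. Also open, as far as these compounds go, is whether the fluoro-to-iodo exchange would read the same with a longer chain in place of the alkyl chain on the shared core.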